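The source may report more compounds than this note shows. Statements on the series, on what has been measured and on what is new or still open speak of the compounds shown alone.

In a functional assay on SMMC-7721 cells (Homo sapiens) for antiproliferative activity, read by MTT assay, with a stated time of 48 h (a higher number here means a weaker inhibitor, a lower number a stronger inhibitor), compound 1 `COCOC/C1=C/C[C@](C)(CCC=C(C)C)/C=C/[C@@H](OC(=O)C=C(C)C)[C@](C)(O)/C=C/C1=O` gives 3250 nM and compound 2 `CC(C)=CCC[C@]1(C)/C=C/[C@@H](OC(=O)C=C(C)C)[C@](C)(O)/C=C/C(=O)/C(CN=[N+]=[N-])=C\C1` gives 3080 nM, so compound 2 stands level with compound 1 within the scatter. Compound 3 `CSC(=S)OC/C1=C/C[C@](C)(CCC=C(C)C)/C=C/[C@@H](OC(=O)C=C(C)C)[C@](C)(O)/C=C/C1=O` differs from compound 2 on a saturated chain carbon bound to a double-bonded ring carbon: a group of 5 heavy atoms (2 carbon, 1 oxygen, 2 sulfur; no ring) in place of a group of 3 heavy atoms (3 nitrogen; no ring), on a saturated chain carbon bound to a double-bonded ring carbon. Within the data shown here, the only measured step at that place, a 1.1-fold lower number from compound 1 to compound 2 (0.02 log units; within the scatter), lies within the scatter. No step beyond the scatter is therefore expected in this assay. The expected step is a 1.0-fold lower number from compound 2 to compound 3 (0.01 log units; within the scatter). For compound 3 the estimated value is 3000 nM, with an expected range of 1300 nM to 7000 nM.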

Compound 3, half-maximal inhibitory concentration: 720 nM
Compound 3: middle estimate off by 4.2-fold (0.62 log units), on the high side, and the stated range ends above it.
By their numbers in this assay, from the lowest: compound 3; then compounds 2 and 1 (each within the scatter of the next).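

In this assay the place on a saturated chain carbon bound to a double-bonded ring carbon proves sensitive to its substituent: the group of 5 heavy atoms carrying sulfur, in place of azido, gives a 4.3-fold lower number from compound 2 to compound 3 (0.63 log units; beyond the scatter), and against methoxymethoxy it gives a 4.5-fold lower number from compound 1 to compound 3 (0.65 log units; beyond the scatter). The level reading from the earlier pair therefore holds only for azido and methoxymethoxy, not for this place as a whole. Nothing at hand accounts for these steps.

From the compounds shown here alone, whether the sulfur atoms are needed stays open, as an all-oxygen methyl carbonate at this place would show. Going by these compounds, how an amine or a longer chain on the sulfur would read also remains unknown.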